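A few compounds are considered here, and "the series" means these few. Any claim that something is new, unique, unknown or untested is made for them only; others in the source may bear on it.

The measured compounds:
compound 1 `COc1ccc(CNc2nc([Se]C)nc3ccccc23)cc1` with 33000 nM;
compound 2 `COc1ccc(CNc2nc([SeH])nc3ccccc23)cc1` with 7110 nM;
compound 3 `CSc1nc(NCCCc2ccccc2)c2ccccc2n1` with 50600 nM.

All three were tested in a functional assay on HTB-54 cells (Homo sapiens) for cytotoxicity, read by MTT assay, with a stated time of 72 h; on this read-out higher numbers stand for weaker inhibition of growth and lower numbers for stronger inhibition of growth. Compound 1 stands second highest of the three numbers. Its nearest neighbour is compound 3, whose value of 50600 nM lies within the scatter of that of compound 1, so no order between these two can be read. Within the data shown here, the only measured step that starts from compound 1 is a 4.6-fold lower number from compound 1 to compound 2 (0.67 log units; beyond the scatter), a change of hydrogen in place of methyl on a selenium; compound 3 differs from compound 1 in more than one place and offers no single step.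

Compound 4 `C[Se]c1nc(NCc2ccccc2)c2ccccc2n1` differs from compound 1 by hydrogen in place of methoxy on an aromatic carbon. Among the measured compounds shown here, no measured step in this set touches the methoxy or any substituent on that aromatic ring, so nothing among the measured compounds speaks directly to this change. Without a comparable step to lean on, the expectation is that compound 4 stays close to compound 1, with a step of a 1.1-fold higher number from compound 1 to compound 4 (0.04 log units; within the scatter) in this assay, not beyond the scatter in either direction. Compound 4 is therefore estimated at 36000 nM, within a range from 14000 nM to 90000 nM.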

Compound 4, concentration for 50% growth inhibition: 74600 nM
Beside the measured number, compound 4's estimate is 2.1-fold (0.32 log units) below it; low and high end bracket the measured number.
By their numbers in this assay, from the lowest: compound 2; then compounds 1, 3 and 4 (each within the scatter of the next, the first and the last beyond it).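

Among these compounds, the step of a 2.3-fold higher number from compound 1 to compound 4 (0.35 log units; beyond the scatter) is the first measured reading of this position, since the earlier compounds spoke only to the group on selenium and left the aromatic ring untouched. It shows that in this assay the change of methoxy to hydrogen, on an aromatic carbon para to a large group, is not silent: the compound that keeps the methoxy gives the stronger inhibition of growth, although the step is modest and rests on this single pair. Nothing at hand explains why the number moves with this change.

The compounds shown leave open whether another group at this place, such as a hydroxyl, an ethoxy or a chlorine atom, would carry the number further in either direction, and whether methoxy itself matters or any group there would do the same. Among the compounds shown here, they also leave open whether this step would keep its direction and size on a compound with hydrogen rather than methyl on the selenium, as compound 2 has, since no pair with that group reads this change.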